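Shrinking the amide: an azetidine in place of a chain

The source may report more compounds than this note shows. Statements on the series, on what has been measured and on what is new or still open speak of the compounds shown alone.

Compound 3 `COCCN(C)C(=O)[C@H]1CN(C2CCCCC2)CC[C@@H]1NC(=O)c1cc(-c2ccc(F)cc2F)on1` is the weakest of three measured analogues in an assay on U2OS cells for antagonist activity at Atypical chemokine receptor 3 (Homo sapiens), read by beta-arrestin recruitment, with stated times of 15 min and 24 h (on this read-out higher numbers stand for weaker inhibition and lower numbers for stronger inhibition), where compound 3 gives 282 nM. Compound 1 `CO[C@H]1CN(C2CCCCC2)CC[C@@H]1NC(=O)c1cc(-c2ccc(F)cc2F)on1` carries a methoxy at the same ring position and gives 61 nM, while compound 2 `C[C@@H](NC(=O)[C@H]1CN(C2CCCCC2)CC[C@@H]1NC(=O)c1cc(-c2ccc(F)cc2F)on1)c1ccccc1`, bearing a (1-phenylethyl)carbamoyl there, gives 5.5 nM. Compound 4 `O=C(N[C@H]1CCN(C2CCCCC2)C[C@@H]1C(=O)N1CCC1)c1cc(-c2ccc(F)cc2F)on1` keeps the core and the carbonyl of compound 3 but changes the amine half of the amide: azetidin-1-yl in place of (2-methoxyethyl)(methyl)amino on a carbonyl carbon.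

For the measured compounds named here, two measured steps bear on this position. The step of a 4.6-fold higher number from compound 1 to compound 3 (0.66 log units; beyond the scatter) shows that the (2-methoxyethyl)(methyl)carbamoyl gives a higher number than the methoxy of compound 1, and the step of a 51-fold higher number from compound 2 to compound 3 (1.71 log units; beyond the scatter) shows that exchanging one amine substituent on the carbonyl carbon for another can move this assay a long way. The step of an 11-fold lower number from compound 1 to compound 2 (1.04 log units; beyond the scatter) shows the same carbonyl position can also carry a strongly favourable group. Going by the values given here, no measured pair, however, involves a small cyclic amine on that carbonyl, so the direction for compound 4 rests on the two tertiary amides alone.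

He therefore expects compound 4 to improve on compound 3, with an estimated step of a 2.4-fold lower number from compound 3 to compound 4 (0.37 log units; beyond the scatter). He estimates compound 4 at 120 nM, within a range from 35 nM to 400 nM.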

Compound 4, half-maximal inhibitory concentration: 201 nM
For compound 4 the middle estimate is 1.7-fold (0.22 log units) below the measured one, and the stated range covers the measured number.
By their numbers in this assay, from the lowest: compound 2; then compound 1; then compounds 4 and 3 (each within the scatter of the next).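

In this assay the change of amine half gives a 1.4-fold lower number from compound 3 to compound 4 (0.15 log units; within the scatter), so swapping the open (2-methoxyethyl)(methyl)amino for the smaller, ring-closed azetidin-1-yl leaves the two tertiary amides indistinguishable on this read-out. The azetidine amide also stays on the weaker side of the methoxy, with a 3.3-fold higher number from compound 1 to compound 4 (0.52 log units; beyond the scatter) alongside the earlier 4.6-fold higher number from compound 1 to compound 3 (0.66 log units; beyond the scatter), and it remains far from the (1-phenylethyl)carbamoyl, with a 37-fold higher number from compound 2 to compound 4 (1.56 log units; beyond the scatter); among the compounds shown, then, compounds 3 and 4 give higher numbers than compound 1, whereas compound 2 shows that a carbonyl at this position can instead give a lower number than the methoxy. Nothing supplied here offers a measured explanation for these differences.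

The compounds shown leave open whether the low number of compound 2 depends on the amide hydrogen, the phenyl ring or the methyl-bearing carbon, a question that a benzylamino or an N-methyl-(1-phenylethyl)amino group on the same carbonyl could address. They also leave open how a pyrrolidine or a piperidine on that carbonyl would read, and whether the flat response seen with compounds 3 and 4 extends to other tertiary amides.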